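Exchanging the amide's aryl ring in an antiproliferative series

A few compounds are considered here, and "the series" means these few. Any claim that something is new, unique, unknown or untested is made for them only; others in the source may bear on it.

Three measured compounds share one core and differ at a single aromatic position. Compound 1 `COc1cc(F)c(NC(=O)c2ccnc(Cl)c2)cc1Nc1nccc(-c2cn(C)c3ccccc23)n1` carries a fluoro there, and in a functional assay on A549 cells (Homo sapiens) for antiproliferative activity, read by MTT assay, with a stated time of 72 h (on this read-out higher numbers stand for weaker inhibition and lower numbers for stronger inhibition), compound 1 gives 6890 nM. Compound 2 `COc1cc(N(C)CCN(C)C)c(NC(=O)c2ccnc(Cl)c2)cc1Nc1nccc(-c2cn(C)c3ccccc23)n1` carries a (2-(dimethylamino)ethyl)(methyl)amino group, and in this assay compound 2 gives 970 nM. Compound 3 `COc1cc(N(C)C)c(NC(=O)c2ccnc(Cl)c2)cc1Nc1nccc(-c2cn(C)c3ccccc23)n1` carries a dimethylamino group, and in this assay compound 3 gives 3430 nM. Compound 3 stands apart from compound 2, since a 3.5-fold higher number from compound 2 to compound 3 (0.55 log units; beyond the scatter) is beyond the scatter, while a 2.0-fold lower number from compound 1 to compound 3 (0.30 log units; within the scatter) is within it; the remaining step, a 7.1-fold lower number from compound 1 to compound 2 (0.85 log units; beyond the scatter), also concerns only that amine position. Compound 4 `COc1cc(N(C)C)c(NC(=O)c2ncccn2)cc1Nc1nccc(-c2cn(C)c3ccccc23)n1` keeps the dimethylamino group of compound 3 and changes a different place: pyrimidin-2-yl in place of 2-chloropyridin-4-yl on a carbonyl carbon. Among the measured compounds shown here, no measured step touches the ring on the carbonyl, so nothing here shows how this exchange moves the number. The expectation is therefore only that a 1.5-fold higher number from compound 3 to compound 4 (0.16 log units; within the scatter) stays within the scatter, with wide uncertainty. Compound 4 is estimated at 5000 nM, in a range from 1000 nM to 25000 nM.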

Compound 4, half-maximal inhibitory concentration: 8640 nM
Estimate against measurement, compound 4: 1.7-fold (0.24 log units) below; the measured number falls inside the stated range.
By their numbers in this assay, from the lowest: compound 2; then compounds 3, 1 and 4 (each within the scatter of the next, the first and the last beyond it).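

The ring on the carbonyl carbon is a place where the number responds, not only the amine position varied across compounds 1, 2 and 3: with the dimethylamino group held fixed, pyrimidin-2-yl in place of 2-chloropyridin-4-yl gives a 2.5-fold higher number from compound 3 to compound 4 (0.40 log units; beyond the scatter) in this assay and so moves beyond the scatter, towards weaker inhibition. This single exchange removes the chlorine and brings a second ring nitrogen at the same time, so the two changes cannot be told apart. Nothing available explains why the number moves.

A pyridin-4-yl ring without chlorine, or a plain phenyl ring, on that carbonyl would help to separate the two changes. Also open, going by these compounds, is whether the exchange moves the number similarly with the (2-(dimethylamino)ethyl)(methyl)amino group of compound 2 in place of dimethylamino.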